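The source may hold more compounds than are shown below. What is called first, only, known or untested is meant among the compounds shown, and "the series" means these compounds.

Three compounds of one series share a core and differ only in the chain on the five-membered ring. Compound 1 `CCCCCCOc1ccc(-n2cnnc2CCCC)cc1` gives 13.6 mg/kg in a functional assay on the whole organism (strain C57B/6) with Mus musculus as the target, in the maximal electroshock model; a lower number here means that less compound is needed, a higher number that more compound is needed for the effect. Compound 2 `CCCCCCOc1ccc(-n2cnnc2CCCCC)cc1` gives 32.8 mg/kg in this assay. For compound 3 `CCCCCCOc1ccc(-n2cnnc2CCCCCC)cc1` this assay reports only a limit, > 40 mg/kg, which is the limit of > 40 mg/kg in this assay, at which 1 of the 3 values shown sits. Among the two numbers, compound 2 holds the higher one, with compound 1 as its nearest neighbour. The steps along the chain run one way: a 2.4-fold higher number from compound 1 to compound 2 (0.38 log units; beyond the scatter), an at least 2.9-fold higher number from compound 1 to compound 3 (0.46 log units; beyond the scatter), and an at least 1.2-fold higher number from compound 2 to compound 3 (0.08 log units; that floor lies within the scatter).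

Compound 4 `CCCCCCOc1ccc(-n2cnnc2-c2ccccc2F)cc1` is not yet measured. It differs from compound 2 in one place: 2-fluorophenyl in place of pentyl on an aromatic carbon. Among the compounds with values here, none of the measured steps exchanges a chain for a ring, so they bear on this change only loosely. They show that lengthening the chain pushes the number upward, and the 2-fluorophenyl group is larger than pentyl, so a further rise is not ruled out, yet a ring of this kind is a different object from a chain, and the direction cannot be read from compounds 1 to 3 alone.

Compound 4 is therefore expected to give about 30 mg/kg in this assay, within a broad range from 10 mg/kg to 90 mg/kg, which would mean an expected step of a 1.1-fold lower number from compound 2 to compound 4 (0.04 log units; within the scatter).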

Compound 4, dose for half-maximal effect: 20.2 mg/kg
Beside the measured number, compound 4's estimate is 1.5-fold (0.17 log units) above it; the measured number falls inside the stated range.
By their numbers in this assay, from the lowest: compounds 1, 4 and 2 (each within the scatter of the next, the first and the last beyond it). At a limit, above all of these: compound 3.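

In this assay, the position on the aromatic carbon between two ring nitrogen atoms accepts a ring as well as a chain: 2-fluorophenyl in place of pentyl gives a 1.6-fold lower number from compound 2 to compound 4 (0.21 log units; within the scatter), and 2-fluorophenyl in place of butyl gives a 1.5-fold higher number from compound 1 to compound 4 (0.17 log units; within the scatter). The upward trend seen along the three chains therefore does not extend to this exchange, even though 2-fluorophenyl has more heavy atoms than pentyl, and compound 4 cannot be separated from compound 1 or compound 2. The comparison with hexyl gives an at least 1.9-fold lower number from compound 3 to compound 4 (0.29 log units; that floor lies within the scatter), and compound 3 itself is known only as a limit, not as a number: the limit of > 40 mg/kg in this assay, at which 1 of the 4 values shown sits.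

As far as these compounds go, how a plain phenyl, a 2-chlorophenyl or a propyl chain would behave at this position remains open, so the part played by the fluorine and the lower end of the chain series cannot be judged. With a single ring-bearing compound shown, it also remains open whether any ring at this position would give a number beyond the scatter of those for the butyl and pentyl compounds.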